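A few compounds are considered here, and "the series" means these few. Any claim that something is new, unique, unknown or untested is made for them only; others in the source may bear on it.

Of the compounds shown here, two of a shared core have been measured in an assay for binding affinity to leukotriene B4 receptor 1 (Homo sapiens); on this read-out lower numbers stand for stronger inhibition and higher numbers for weaker inhibition. Compound 2, `O=C(O)CCCCCOc1cc(-c2ccccc2)cc(-c2ccccc2)n1`, gives 30 nM. Among the compounds with values here, the only other measured compound, compound 1, `CC(CCCCOc1cc(-c2ccccc2)cc(-c2ccccc2F)n1)C(=O)O`, gives 18 nM in this assay; the gap between compound 2 and compound 1 lies within the usual scatter, so the two cannot be told apart on these numbers.

The next compound, compound 3, `CC(CCCCOc1cc(-c2ccccc2)cc(-c2ccccc2)n1)C(=O)O`, is not yet measured. It differs from compound 2 in one place: methyl in place of hydrogen on a saturated chain carbon bound to a carbonyl carbon and a saturated chain carbon. Compound 1 carries the same methyl on its chain, but it also differs from compound 2 elsewhere, so no clean comparison of this single change exists among the measured compounds. With so little to go on, the expected step is small, and the step from compound 2 to compound 3 in this assay is estimated at a 1.4-fold lower number from compound 2 to compound 3 (0.13 log units; within the scatter), not beyond the scatter. Compound 3 is expected to give about 22 nM, with a likely range from 8 nM to 60 nM.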

Compound 3, half-maximal inhibitory concentration: 30 nM
Estimate against measurement, compound 3: 1.4-fold (0.13 log units) below; measured number inside the range.
By their numbers in this assay, from the lowest: compounds 1, 2 and 3 (each within the scatter of the next).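

In this assay, within the data shown here, the single change gives no change at the digits printed from compound 2 to compound 3 (within the scatter), so this methyl on the saturated chain carbon bound to a carbonyl carbon and a saturated chain carbon, seen alone for the first time, has no effect that these numbers can detect. The other single change, hydrogen in place of fluoro on an aromatic carbon, gives a 1.7-fold higher number from compound 1 to compound 3 (0.22 log units; within the scatter), so that swap also leaves the compounds indistinguishable on this read-out. No other data here bear on these results.

Methyl is the only group shown at this chain carbon, so it remains open whether a larger group such as ethyl, or a polar one such as hydroxyl, would be accommodated as well. Going by these compounds, it is also open how a shorter chain, or an amide in place of the carboxylic acid, would read.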